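Thiadiazolyl group on the amide nitrogen of compound 2

The source may hold more compounds than are shown below. What is called first, only, known or untested is meant among the compounds shown, and "the series" means these compounds.

Of the compounds shown here, two on a shared core have numbers so far. In an in vivo ADME assay on the whole organism for pharmacokinetics, with Mus musculus as the target, at a dose of 25 mg/kg by the oral route (on this read-out higher numbers stand for higher oral bioavailability and lower numbers for lower oral bioavailability), compound 1 (`Nc1nccn2c1c(-c1ccc3ccc(-c4ccccc4)nc3c1F)nc2[C@H]1CC[C@H](C(=O)O)CC1`) gives 51%. Compound 2 (`Nc1nccn2c1c(-c1ccc3ccc(-c4ccccc4)nc3c1F)nc2[C@H]1CC[C@H](C(N)=O)CC1`) gives 24%, the lower of the two numbers.

Compound 3 (`Nc1nccn2c1c(-c1ccc3ccc(-c4ccccc4)nc3c1F)nc2[C@H]1CC[C@H](C(=O)Nc2nncs2)CC1`) has 1,3,4-thiadiazol-2-yl in place of hydrogen on an amide-type nitrogen.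

Among the measured compounds shown here, only one measured step bears on this change: a number 27 percentage points lower from compound 1 to compound 2 (beyond the scatter). This modest step, beyond the scatter, has amino in place of hydroxy on a carbonyl carbon, so it concerns the same carbonyl carbon but not a ring-bearing group on the nitrogen. For the measured compounds named here, no measured compound carries any substituent on that nitrogen, so neither the size nor the direction of the change is established by the data. The most likely outcome in this assay is therefore no step beyond the scatter, although a step as large as the measured one remains possible. The expected step is a number 2 percentage points lower from compound 2 to compound 3 (within the scatter).

In this assay the estimate for compound 3 is 22%, expected to lie between 7% and 45%.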

Compound 3, oral bioavailability: 5%
Estimate against measurement, compound 3: 17 percentage points above; measured number outside the range, below it.
By their numbers in this assay, from the lowest: compound 3; then compound 2; then compound 1.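

In this assay, among the compounds shown here, the amide nitrogen proves sensitive to substitution: with 1,3,4-thiadiazol-2-yl in place of the amide hydrogen, the step is a number 19 percentage points lower from compound 2 to compound 3 (beyond the scatter), the first measured change at this nitrogen. Both changes at this end of the molecule now point the same way, with the exchange of hydroxy for amino on the carbonyl carbon followed by a further loss on adding the ring; taken together, the change from the carboxylic acid to the thiadiazolyl amide is a number 46 percentage points lower from compound 1 to compound 3 (beyond the scatter), and none of the three compounds goes against this order. No measurement at hand bears on what lies behind the lower number for compound 3.

The compounds shown do not separate an effect of this particular ring from an effect of any substituent on the amide nitrogen, and a single substituent gives no trend at this position. A methyl group on that nitrogen, or a phenyl ring in place of 1,3,4-thiadiazol-2-yl, would help to separate the two in this assay.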